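A few compounds are considered here, and "the series" means these few. Any claim that something is new, unique, unknown or untested is made for them only; others in the source may bear on it.

Measured in a functional assay on HeLa cells (Homo sapiens) for cytotoxicity, read by sulforhodamine B assay, with a stated time of 48 h; a higher number here means a weaker inhibitor, a lower number a stronger inhibitor:
- compound 1 `C=CCOc1ccc(F)cc1C(=O)c1cccnc1`: 93000 nM
- compound 2 `C=CCOc1c(Cl)cccc1C(=O)c1cccnc1`: 100000 nM

Only these two numbers exist so far. Compound 2 gives 100000 nM, within the scatter of compound 1 at 93000 nM.

Compound 3 `O=C(c1cccnc1)c1cccc(Cl)c1O` has hydrogen in place of allyl on an oxygen on an aromatic ring, allyloxy to hydroxy: hydrogen in place of allyl on an oxygen on an aromatic ring.

Among the compounds with values here, no measured pair shows a step of this kind, so the expectation in this assay is loose: a small move to a lower number, possibly none beyond the scatter. The expected change is a 1.7-fold lower number from compound 2 to compound 3 (0.22 log units; within the scatter). For compound 3 the estimated value is 60000 nM, with an expected range of 15000 nM to 150000 nM.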

Compound 3, half-maximal inhibitory concentration: 21000 nM
Compound 3: the middle estimate sits 2.9-fold (0.46 log units) above what was measured, within the range that was stated.
By their numbers in this assay, from the lowest: compound 3; then compounds 1 and 2 (each within the scatter of the next).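

Allyloxy to hydroxy on the oxygen on an aromatic ring gives the first step beyond the scatter in this assay, with a 4.8-fold lower number from compound 2 to compound 3 (0.68 log units; beyond the scatter) as the change. The earlier compounds shown here sat within the scatter of each other, so they showed nothing about this oxygen; here, the allyl group is not required for the activity seen, and its removal gives a lower number. No measurement at hand bears on the reason for this step.

Still open, from the compounds shown here alone, is how a methyl ether, a longer chain or an amine on this oxygen would read. Also open, going by these compounds, is whether the same step holds for the hydroxy counterpart of compound 1.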